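One Hydroxyl Fewer on the Oxolane Group of Compound 1

A few compounds are considered here, and "the series" means these few. Any claim that something is new, unique, unknown or untested is made for them only; others in the source may bear on it.

In a functional assay on A549 cells (Homo sapiens) for cytotoxicity, read by MTT assay, with a stated time of 72 h (a lower number here means a stronger inhibitor, a higher number a weaker inhibitor), compound 1 `O=C1c2c[n+]([O-])c3ccccc3c2C(=O)c2c1c1ccccc1n2Cc1cn([C@H]2O[C@H](CO)[C@@H](O)[C@H]2O)nn1` gives 2680 nM, the weakest of the three measured compounds. Compound 2 `O=C1c2c[n+]([O-])c3ccccc3c2C(=O)c2c1c1ccccc1n2CCCCn1ccnc1` gives 170 nM and compound 3 `CCCN1CCN(CCCCn2c3c(c4ccccc42)C(=O)c2c[n+]([O-])c4ccccc4c2C3=O)CC1` gives 320 nM. Neither carries an oxolane group, and both differ from compound 1 in more than that group, so their lower numbers say little here. Compound 4 `O=C1c2c[n+]([O-])c3ccccc3c2C(=O)c2c1c1ccccc1n2Cc1cn([C@H]2C[C@H](O)[C@@H](CO)O2)nn1` is still unmeasured and differs from compound 1 in one place, on an aromatic nitrogen: 4-hydroxy-5-(hydroxymethyl)oxolan-2-yl in place of 3,4-dihydroxy-5-(hydroxymethyl)oxolan-2-yl on an aromatic nitrogen. Within the data shown here, the only measured step, a 1.9-fold higher number from compound 2 to compound 3 (0.27 log units; within the scatter), lies within the scatter and changes a different group, so nothing measured tests this swap. The estimated step is a 1.3-fold lower number from compound 1 to compound 4 (0.11 log units; within the scatter), not expected to exceed the scatter. Compound 4 is expected at 2100 nM, within a range of 750 nM to 5500 nM.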

Compound 4, half-maximal inhibitory concentration: 350 nM
The estimate for compound 4 lay 6.0-fold (0.78 log units) above the measured number, and the stated range ends above it.
By their numbers in this assay, from the lowest: compounds 2, 3 and 4 (each within the scatter of the next, the first and the last beyond it); then compound 1.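

In this assay, among these compounds, the swap of 3,4-dihydroxy-5-(hydroxymethyl)oxolan-2-yl for 4-hydroxy-5-(hydroxymethyl)oxolan-2-yl gives a 7.7-fold lower number from compound 1 to compound 4 (0.88 log units; beyond the scatter) and is the first measured step to touch this group. It shows that the number responds to the group on this aromatic nitrogen, and that removing a single hydroxyl is enough to move it beyond the scatter. Nothing available explains why the number falls. Still open, going by these compounds, is whether an amine or a fluorine atom in place of that hydroxyl would give a number closer to compound 1 or to compound 4. On these data alone, whether removing the other hydroxyl groups of the oxolane would matter as much also remains open.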